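The source may report more compounds than this note shows. Statements on the series, on what has been measured and on what is new or still open speak of the compounds shown alone.

The measured compounds:

Compound 1, `CCCc1cnc(N2CCC(C3Cc4cc(C5=CCN(S(=O)(=O)CCC)CC5)cc(F)c4O3)CC2)nc1`, gives 93%.
Compound 2, `CCCc1cnc(N2CCC(C3(C)Cc4cc(C5=CCN(S(=O)(=O)CCC)CC5)ccc4O3)CC2)nc1`, gives 48%.
Compound 3, `CCCc1cnc(N2CCC(C3Cc4cc(C5=CCN(S(=O)(=O)CCCO)CC5)cc(F)c4O3)CC2)nc1`, gives 92%.

These three compounds were examined in a functional assay on HEK293 cells with Glucose-dependent insulinotropic receptor (Homo sapiens) as the target, read by cAMP accumulation, with a stated time of 60 min; on this read-out lower numbers stand for smaller maximal responses and higher numbers for larger maximal responses. Compound 1 and compound 3 share one core and differ only by hydroxy in place of hydrogen on a saturated chain carbon, three bonds along the chain from a sulfonyl sulfur. Across that pair the step is a number 1 percentage points lower from compound 1 to compound 3 (within the scatter), so the two values are within the scatter of each other and no change can be read from them. Compound 2 is built on a different core; the difference between the core of compound 1 and the core of compound 2 is not broken down here. Its value in this assay is the lowest of the three, and the gaps to compound 1 and to compound 3 are each beyond the scatter.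

The unmeasured compound 4, `CCCc1cnc(N2CCC(C3(C)Cc4cc(C5=CCN(S(=O)(=O)CCCO)CC5)ccc4O3)CC2)nc1`, is derived from compound 2 by hydroxy in place of hydrogen on a saturated chain carbon, three bonds along the chain from a sulfonyl sulfur. For the measured compounds named here, this is the same change, at the same place, as the one that separates compound 3 from compound 1. Because the measured instance of it, a number 1 percentage points lower from compound 1 to compound 3 (within the scatter), stayed within the scatter, the expected step from compound 2 to compound 4 is likewise small, estimated as a number 1 percentage points lower from compound 2 to compound 4 (within the scatter). This rests on a single measured pair on a different core, so the expectation is held loosely. Compound 4 is therefore expected to give about 47% in this assay, with a likely range from 33% to 62%.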

Compound 4, largest response reached (Emax), in percent of the reference or control that the assay uses: 78%
Compound 4: the middle estimate sits 31 percentage points below what was measured; measured number above the stated range.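

In this assay, hydroxy in place of hydrogen on a saturated chain carbon, three bonds along the chain from a sulfonyl sulfur, does not carry over from one core to the other with the same size of effect: the same change on two cores in this assay, a number 1 percentage points lower (within the scatter) from compound 1 to compound 3 and a number 30 percentage points higher (beyond the scatter) from compound 2 to compound 4, 31 percentage points apart, beyond the scatter of two such steps

On the core of compound 2, the propyl to 3-hydroxypropyl exchange gives a number 30 percentage points higher from compound 2 to compound 4 (beyond the scatter), so a step that leaves no readable change on one core cannot be assumed to be equally silent on the other. For the compounds shown here, what this does not show is which feature of the cores goes with the difference, since the two cores are not broken down into single changes and each core contributes only one pair, which leaves the reason for the difference unknown and gives no general rule for the series.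

The compounds shown leave open whether a different group at the end of the sulfonyl chain, such as a methoxy group, an amine or a carboxylic acid, would follow the hydroxy group on either core. They also leave open whether a 2-hydroxyethyl group or a longer hydroxy-bearing chain would give a similar step on the core of compound 2.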